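The compounds below may be only part of what the source reports. "The series", "measured", "known", "first", "only" and "open" are said of these compounds alone.

In a functional assay on MDA-MB-231 cells (Homo sapiens) for inhibition, read by MTT assay, with a stated time of 72 h (a lower number here means a stronger inhibitor, a higher number a weaker inhibitor), compound 1 `COc1ccc(C=c2s/c(=C3\C(=O)Nc4cc(F)ccc43)n(CCN(C)C)c2=O)cc1` gives 2090 nM. Compound 2 `CN(C)CCn1c(=O)c(=Cc2ccc(O)cc2)s/c1=C1\C(=O)Nc2ccc(F)cc21` gives 4200 nM in this assay, the upper of the two numbers shown, but its gap to compound 1 lies within the scatter, so the two read as equivalent. Compound 3 `CN(C)CCn1c(=O)c(=Cc2ccc(O)cc2)s/c1=C1\C(=O)Nc2ccc(Br)cc21` differs from compound 2 by bromo in place of fluoro on an aromatic carbon. Among the measured compounds shown here, no measured pair covers this change. The step from compound 2 to compound 3 in this assay is expected to be small, within the scatter, with no set direction: a 1.3-fold lower number from compound 2 to compound 3 (0.12 log units; within the scatter). Compound 3 is therefore estimated at 3200 nM in this assay, with a range of 1000 nM to 10000 nM.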

Compound 3, half-maximal inhibitory concentration: 2520 nM
For compound 3 the middle estimate is 1.3-fold (0.10 log units) above the measured one; measured number inside the range.
By their numbers in this assay, from the lowest: compounds 1, 3 and 2 (each within the scatter of the next).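

Notes on the halogen position: in this assay, the step from fluoro to bromo gives a 1.7-fold lower number from compound 2 to compound 3 (0.22 log units; within the scatter), the first step measured at this aromatic carbon. It lies within the scatter, so compound 2 and compound 3 read as equivalent and this exchange of one halogen for another shows no clear effect on the number here. No supporting evidence bears on this result.

Open, on these data alone, is whether a nitrile or an amine on this aromatic carbon would give a step beyond the scatter. Also open, as far as these compounds go, is whether chloro would stay equivalent to fluoro and bromo.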